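The compounds below may be only part of what the source reports. "The series", "measured", "known", "first", "only" and "open" are said of these compounds alone.

Of the compounds shown here, three measured so far share one core and differ only in the groups hanging from it. Compound 1 `O=C(NCc1cn(Cc2ccc(Cl)cc2)nn1)c1cn(-c2ccccc2)nc1-c1ccccc1` gives 8700 nM in a functional assay on MIA PaCa-2 cells (Homo sapiens) for antiproliferative activity, read by sulforhodamine B assay, with a stated time of 48 h; a lower number here means a stronger inhibitor of growth, a higher number a weaker inhibitor of growth. Compound 2 `O=C(NCc1cn(Cc2ccc(C(F)(F)F)cc2)nn1)c1cn(-c2ccccc2)nc1-c1ccccc1` gives 17700 nM in this assay, and there is a 2.0-fold higher number from compound 1 to compound 2 (0.31 log units; beyond the scatter). Compound 3 `O=C(NCc1cn(Cc2ccc(C(F)(F)F)cc2)nn1)c1cn(-c2ccccc2)nc1-c1ccc(F)cc1` gives 760 nM in this assay, and there is a 23-fold lower number from compound 2 to compound 3 (1.37 log units; beyond the scatter). Compound 3 therefore stands lowest of the three numbers, with compound 1 the nearest and compound 2 the furthest, both gaps beyond the scatter.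

Compound 4 `COc1cc(Cn2cc(CNC(=O)c3cn(-c4ccccc4)nc3-c3ccc(F)cc3)nn2)cc(OC)c1OC` differs from compound 3 by 3,4,5-trimethoxyphenyl in place of 4-(trifluoromethyl)phenyl on a saturated chain carbon bound to an aromatic nitrogen. Going by the values given here, only one measured step touches this phenyl ring: a 2.0-fold higher number from compound 1 to compound 2 (0.31 log units; beyond the scatter), a modest change from one small substituent to another. Among the compounds with values here, no measured compound carries the trimethoxyphenyl, so the size of this step is unknown; a modest step in either direction, or none beyond the scatter, is expected. Compound 4 is estimated at 1000 nM in this assay, with a range from 250 nM to 4000 nM, which means an expected 1.3-fold higher number from compound 3 to compound 4 (0.12 log units; within the scatter).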

Compound 4, concentration for 50% growth inhibition: 5200 nM
Compound 4: middle estimate off by 5.2-fold (0.72 log units), on the low side, and the stated range ends below it.
By their numbers in this assay, from the lowest: compound 3; then compounds 4 and 1 (each within the scatter of the next); then compound 2.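

Changing the ring on the saturated chain carbon bound to an aromatic nitrogen can matter more than the earlier chloro-to-trifluoromethyl swap suggested: that swap gave a 2.0-fold higher number from compound 1 to compound 2 (0.31 log units; beyond the scatter), while replacing 4-(trifluoromethyl)phenyl with 3,4,5-trimethoxyphenyl gives a 6.8-fold higher number from compound 3 to compound 4 (0.84 log units; beyond the scatter) in this assay. Thus, with the fluoro group present elsewhere on the molecule, the entering ring, which brings 3 hydrogen-bond acceptors where the leaving ring has 0, is the weaker growth inhibitor of the pair. No measurement shown here explains this loss of activity.

From the compounds shown here alone, it remains open whether a single methoxy group, a plain phenyl ring or a ring carrying an amine would sit nearer compound 3 or compound 4. It is also unknown whether the trimethoxyphenyl swap would cost as much without that fluoro group.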